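From methoxycarbonyl to benzyloxycarbonyl in compound 3

A few compounds are considered here, and "the series" means these few. Any claim that something is new, unique, unknown or untested is made for them only; others in the source may bear on it.

Values from (a functional assay on HT-29 cells (Homo sapiens) for cytotoxicity, read by MTT assay; a lower number here means a stronger inhibitor, a higher number a weaker inhibitor):
- compound 1 (`C=C1C(=O)[C@]23C[C@@]1(I)CC[C@H]2[C@@]12C=CC(=O)[C@](C)(C(=O)O1)[C@H]2[C@@H]3C(=O)OCc1ccccc1`) gives (50200 nM)
- compound 2 (`C=C1C(=O)[C@]23C[C@@]1(OCC)CC[C@H]2[C@@]12C=CC(=O)[C@](C)(C(=O)O1)[C@H]2[C@@H]3C(=O)OC`) gives (34100 nM)

Only these two compounds have been measured so far. Their numbers lie within the usual scatter of each other, so compound 2 stands level with compound 1 and the two cannot be ranked.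

Compound 3 (`C=C1C(=O)[C@]23C[C@@]1(OCC)CC[C@H]2[C@@]12C=CC(=O)[C@](C)(C(=O)O1)[C@H]2[C@@H]3C(=O)OCc1ccccc1`) has not yet been measured. It differs from compound 2 in one place (phenyl in place of hydrogen on a saturated chain carbon bound to an oxygen next to a carbonyl group), with phenyl in place of hydrogen on a saturated chain carbon bound to an oxygen next to a carbonyl group, so that methoxycarbonyl becomes benzyloxycarbonyl. Among the measured compounds shown here, no step between measured compounds shows what such a change does in (this assay). For the measured compounds named here, the only guide is the narrow spread of the two values, with compound 1 at (50200 nM) and compound 2 at (34100 nM), so no step beyond the scatter is expected in either direction. The estimated change is (a 1.1-fold higher number from compound 2 to compound 3 (0.05 log units; within the scatter)), which would stay inside the scatter. For compound 3 the expected value is (38000 nM), with an estimated range from (15000 nM) to (90000 nM).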

Compound 3, half-maximal inhibitory concentration: 23300 nM
Compound 3: the middle estimate sits 1.6-fold (0.21 log units) above what was measured; low and high end bracket the measured number.
By their numbers in this assay, from the lowest: compounds 3, 2 and 1 (each within the scatter of the next, the first and the last beyond it).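

In this assay, the change from methoxycarbonyl to benzyloxycarbonyl gives a 1.5-fold lower number from compound 2 to compound 3 (0.17 log units; within the scatter), so phenyl in place of hydrogen on a saturated chain carbon bound to an oxygen next to a carbonyl group leaves the number level with that of the methoxycarbonyl compound. With benzyloxycarbonyl held constant, ethoxy in place of iodo on a saturated ring carbon gives a 2.2-fold lower number from compound 1 to compound 3 (0.33 log units; beyond the scatter), the only step among these compounds that is beyond the scatter, and it remains modest. Nothing available accounts for either step or bears on why the benzyloxycarbonyl change stays within the scatter.

The compounds shown leave open whether an amine or a longer chain in place of ethoxy on that saturated ring carbon would give a larger step than the one seen with ethoxy and iodo. They also leave open whether a carboxylic acid in place of the methoxycarbonyl or benzyloxycarbonyl group would stay as level as these two do, and whether the step from iodo to ethoxy would recur with methoxycarbonyl in place of benzyloxycarbonyl.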